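A few compounds are considered here, and "the series" means these few. Any claim that something is new, unique, unknown or untested is made for them only; others in the source may bear on it.

Three compounds built on one shared core were tested in an ADME assay on NIH3T3 cells (Mus musculus) for cytotoxicity, read by MTT assay; on this read-out higher numbers stand for weaker inhibition and lower numbers for stronger inhibition. Compound 1 `N#Cc1c(-c2ccccc2O)c(C#N)c(=O)n(/N=C/c2cn(-c3ccccc3)nc2-c2ccccc2)c1N` gives 162 ug/mL, compound 2 `N#Cc1c(-c2ccccc2Cl)c(C#N)c(=O)n(/N=C/c2cn(-c3ccccc3)nc2-c2ccccc2)c1N` gives 84 ug/mL, and compound 3 `N#Cc1c(-c2cccc(F)c2)c(C#N)c(=O)n(/N=C/c2cn(-c3ccccc3)nc2-c2ccccc2)c1N` gives 154 ug/mL. On these numbers compound 2 sits at the low end of the three, yet both a 1.9-fold lower number from compound 1 to compound 2 (0.29 log units; within the scatter) and a 1.8-fold higher number from compound 2 to compound 3 (0.26 log units; within the scatter) fall within the usual scatter, so the three cannot be told apart with confidence.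

Compound 4 `N#Cc1c(-c2ccc(F)cc2)c(C#N)c(=O)n(/N=C/c2cn(-c3ccccc3)nc2-c2ccccc2)c1N` differs from compound 2 in one place: 4-fluorophenyl in place of 2-chlorophenyl on an aromatic carbon. Among the measured compounds shown here, two measured steps bear on this change. The first is a 1.8-fold higher number from compound 2 to compound 3 (0.26 log units; within the scatter), which also replaced the 2-chlorophenyl with a fluorophenyl on that aromatic carbon. The second is a 1.9-fold lower number from compound 1 to compound 2 (0.29 log units; within the scatter), which swapped hydroxy for chloro on the same aromatic carbon. Both stayed within the scatter, and no step larger than these is seen anywhere among the three. For compound 4 the expectation in this assay is therefore no step beyond the scatter, a 1.4-fold higher number from compound 2 to compound 4 (0.15 log units; within the scatter). Compound 4 is estimated at 120 ug/mL, with a likely range from 65 ug/mL to 230 ug/mL.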

Compound 4, half-maximal inhibitory concentration: > 200 ug/mL
Compound 4: no number, only a limit (the forecaster's own chance of this, stated with the estimate: 10%); middle value at least 1.6-fold (0.22 log units) away from the limit.
By their numbers in this assay, from the lowest: compounds 2, 3 and 1 (each within the scatter of the next). At a limit, above all of these: compound 4.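

In this assay compound 4 gives > 200 ug/mL, which is a limit of the assay and not a number: the limit of > 200 ug/mL in this assay, at which 1 of the 4 values shown sits. Even so, this change yields the first step at this position, opposite the ring nitrogen, that clears the scatter: an at least 2.3-fold higher number from compound 2 to compound 4 (0.37 log units; beyond the scatter), and its full size stays unknown. The other two steps, an at least 1.2-fold higher number from compound 3 to compound 4 (0.11 log units; that floor lies within the scatter) and an at least 1.2-fold higher number from compound 1 to compound 4 (0.09 log units; that floor lies within the scatter), have floors that do not clear the scatter, so the limit separates only the first pair.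

As far as these compounds go, whether the step comes from losing the 2-chlorophenyl or from gaining the 4-fluorophenyl remains open. From the compounds shown here alone, it is also open what a 4-chlorophenyl, or a phenyl carrying an amine or a carboxylic acid, would give at this position.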